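The source may report more compounds than this note shows. Statements on the series, on what has been measured and on what is new or still open speak of the compounds shown alone.

Measured compounds in an assay on HEK293 cells for positive allosteric modulation of metabotropic glutamate receptor 2 (Rattus norvegicus), read by thallium flux; on this read-out lower numbers stand for smaller maximal responses and higher numbers for larger maximal responses:
- compound 1, `O=C1c2ccc(OCc3cccc(-c4ccc(Cl)cc4F)c3)cc2CN1C1CCCC1`: "not determined" (no result reported)
- compound 2, `O=C(O)c1cc(-c2cccc(COc3ccc4c(=O)n(CC5CC5)sc4c3)c2)ccc1Cl`: 38.4%
- compound 3, `O=C(O)c1cc(-c2cccc(COc3ccc4c(c3)CN(C3CCCC3)C4=O)c2)ccc1O`: 90.1%

Compound 2 stands lowest of the two numbers available; compound 3 lies far above it, a gap beyond the usual scatter. Compound 1 contributes no number.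

Compound 4, `O=C(O)c1cc(-c2cccc(COc3ccc4c(=O)n(C5CC5)sc4c3)c2)ccc1Cl`, differs from compound 2 by cyclopropyl in place of cyclopropylmethyl on an aromatic nitrogen. For the measured compounds named here, no pair of measured compounds covers this particular change, so no measured step gives a direct guide. A small step is expected, in either direction or none beyond the scatter: a number 5.6 percentage points higher from compound 2 to compound 4 (within the scatter) is the estimated shift from compound 2 to compound 4. Compound 4 is therefore expected to reach 44%, with a range from 25% to 68%.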

Compound 4, largest response reached (reported as percent of maximum), in percent of the reference or control that the assay uses: 70.6%
Compound 4: the middle estimate sits 26.6 percentage points below what was measured, outside the stated range (above it).
By their numbers in this assay, from the lowest: compound 2; then compound 4; then compound 3.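

In this assay, cyclopropyl in place of cyclopropylmethyl on the aromatic nitrogen gives a number 32.2 percentage points higher from compound 2 to compound 4 (beyond the scatter). The maximal response therefore depends on the group at this position, even though the three-membered ring of carbon is present on both sides of the change. The data offer no measurement that accounts for this step.

Open, going by these compounds, is how a cyclobutyl, an isopropyl or a longer chain on this nitrogen would compare. Also open, on these data alone, is whether the same change would carry over to the core of compound 3.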